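A few compounds are considered here, and "the series" means these few. Any claim that something is new, unique, unknown or untested is made for them only; others in the source may bear on it.

Working notes on the series. Compound 1 `O=C(COc1ccc2cc(/C=C3/SC(=O)NC3=O)ccc2c1)Nc1ccc(F)cc1` in an assay on isolated protein for inhibition of histone deacetylase 8 (Homo sapiens), with a stated time of 1 h (on this read-out higher numbers stand for weaker inhibition and lower numbers for stronger inhibition), gives 6600 nM. Compound 2 `Cc1cccc(NC(=O)COc2ccc3cc(/C=C4/SC(=O)NC4=O)ccc3c2)n1` in this assay gives 7500 nM, which is the higher of the two numbers shown, with the step of a 1.1-fold higher number from compound 1 to compound 2 (0.06 log units; within the scatter) within the scatter. Compound 3 `O=C(COc1ccc2cc(/C=C3/SC(=O)NC3=O)ccc2c1)Nc1ccc(Br)c(Br)c1` in this assay reaches only a limit, > 50000 nM, and not a number, so the third value is known only as the limit of > 50000 nM in this assay, at which 1 of the 3 values shown sits. The steps to it, an at least 7.5-fold higher number from compound 1 to compound 3 (0.87 log units; beyond the scatter) and an at least 6.6-fold higher number from compound 2 to compound 3 (0.82 log units; beyond the scatter), both weaken inhibition.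

Compound 4 `O=C(COc1ccc2cc(/C=C3/SC(=O)NC3=O)ccc2c1)Nc1ccc(Cl)c(Cl)c1` differs from compound 2 by 3,4-dichlorophenyl in place of 6-methylpyridin-2-yl on an amide-type nitrogen. The nearest measured step is the one to the 3,4-dibromophenyl amide, an at least 6.6-fold higher number from compound 2 to compound 3 (0.82 log units; beyond the scatter), and the 3,4-dichlorophenyl amide of compound 4 is its closest analogue among the structures shown. Compound 4 is therefore expected to give a weaker number than compound 2, with a step of about a 4.0-fold higher number from compound 2 to compound 4 (0.60 log units; beyond the scatter), possibly again reaching the limit. The estimate for compound 4 in this assay is 30000 nM, with a range from 10000 nM to 100000 nM.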

Compound 4, half-maximal inhibitory concentration: > 50000 nM
Compound 4 gave a limit, no number; the forecaster's own chance of this, stated with the estimate: 40%; middle value at least 1.6-fold (0.22 log units) from the limit.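

In this assay compound 4 reaches only a limit, > 50000 nM, and not a number. Placing 3,4-dichlorophenyl on the amide-type nitrogen gives an at least 6.6-fold higher number from compound 2 to compound 4 (0.82 log units; beyond the scatter) and an at least 7.5-fold higher number from compound 1 to compound 4 (0.87 log units; beyond the scatter), so the loss of inhibition seen with 3,4-dibromophenyl is not confined to that one group and now holds for both dihalogenated phenyl amides shown, compound 3 and compound 4. The step between compound 3 and compound 4 cannot be read, because both stay at the limit: the limit of > 50000 nM in this assay, at which 2 of the 4 values shown sit.

On these data alone, whether this loss needs both halogens, or only one at a given place, remains open. A 3-chlorophenyl or 4-chlorophenyl amide would separate the two chlorines of compound 4, and a 3,4-dimethylphenyl amide would show whether halogen is needed at all.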